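Extending the amine-bearing chain on compound 3

The compounds below may be only part of what the source reports. "The series", "measured", "known", "first", "only" and "open" are said of these compounds alone.

Compound 3 `COc1cc(/C=C/C(=O)Nc2ccccc2)ccc1OCCCCCN1CCCCC1` carries the highest of the three numbers in a physicochemical assay for lipophilicity, using the shake flask method, measured as octanol-water partition, at pH 7.4 (a higher number here means a more lipophilic compound, a lower number a more polar compound), where compound 3 gives 1.65; compound 1 `CCN(CC)CCCCOc1ccc(/C=C/C(=O)Nc2ccccc2)cc1OC` gives 1.59 and compound 2 `COc1cc(/C=C/C(=O)Nc2ccccc2)ccc1O` gives 1.42, and both lie within the scatter of compound 3, so no order among the three can be claimed. Compound 4 `CCN(CC)CCCCCCCCOc1ccc(/C=C/C(=O)Nc2ccccc2)cc1OC` is not yet measured. It differs from compound 3 in one place: 3-(diethylamino)propyl in place of piperidin-1-yl on a saturated chain carbon, five bonds along the chain from an oxygen on an aromatic ring. Going by the values given here, two measured steps bear on this. The step of a number 0.06 log units higher from compound 1 to compound 3 (within the scatter) shows that exchanging diethylamino for the piperidinyl ring at the chain end hardly moves the number, and the step of a number 0.17 log units lower from compound 1 to compound 2 (within the scatter) shows that even removing the whole 4-(diethylamino)butyl group stays within the scatter. Among the compounds with values here, neither step, however, covers a chain as long as the one in compound 4, so the data give no direct anchor for the extension itself. Weighing the small measured steps against the additional chain atoms counted in the change, an upward step of a number 0.45 log units higher from compound 3 to compound 4 (beyond the scatter) in this assay is expected for compound 4, but with a wide range. Compound 4 is therefore estimated at 2.1, between 1.5 and 2.9.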

Compound 4, partition coefficient: 1.75
Compound 4: middle estimate off by 0.35 log units, on the high side, and the stated range covers the measured number.
By their numbers in this assay, from the lowest: compounds 2, 1, 3 and 4 (each within the scatter of the next, the first and the last beyond it).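

In this assay, 4-(diethylamino)butyl in place of diethylamino, on a saturated chain carbon four bonds along the chain from an oxygen on an aromatic ring, gives a number 0.16 log units higher from compound 1 to compound 4 (within the scatter) and the exchange of piperidin-1-yl for 3-(diethylamino)propyl gives a number 0.10 log units higher from compound 3 to compound 4 (within the scatter), so at this place a chain as long as that of compound 4 stays within the scatter of both shorter chains. Compound 2 at 1.42 and compound 4 at 1.75 are the first pair among these compounds to lie beyond the scatter of each other, whereas the earlier compounds showed no such separation. Nothing shown here accounts for these numbers.

The compounds shown leave open how the number responds to a chain end other than these two amines, such as a carboxylic acid or a morpholin-4-yl ring, and whether a longer chain than that of compound 4 would move beyond the scatter of compound 1 and compound 3. Going by these compounds alone, they also hold no pair in which the chain grows while the piperidin-1-yl end stays, so chain length and chain end cannot be told apart in the change that leads to compound 4 from compound 3.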